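This account rests on a few compounds, and the source may have more. Where it says the series, first, only, none or still open, it means among the compounds named here.

Measured compounds:
compound 1 `O=C(/C=C\Nc1ccc(O)cc1)c1cn(-c2ccccc2)nc1-c1ccc(F)cc1`, in an ADME assay on HaCaT cells (Homo sapiens) for antiproliferative activity, read by MTT assay, with a stated time of 48 h (on this read-out lower numbers stand for stronger inhibition and higher numbers for weaker inhibition), compound 1 gives 16300 nM
compound 2 `COc1cc(N/C=C\C(=O)c2cn(-c3ccccc3)nc2-c2ccc(F)cc2)cc(OC)c1OC`, compound 2 gives 32800 nM
compound 3 `O=C(/C=C\Nc1ccc(O)cc1)c1cn(-c2ccccc2)nc1-c1ccc(Cl)cc1`, compound 3 gives 22600 nM

Compound 2 stands at the highest of the three numbers, yet its gaps to compound 3 and to compound 1 both lie within the scatter. Going by the values given here, the single measured step, a 1.4-fold higher number from compound 1 to compound 3 (0.14 log units; within the scatter), is also within the scatter. Compound 4 `COc1cc(N/C=C\C(=O)c2cn(-c3ccccc3)nc2-c2cc(OC)c(OC)c(OC)c2)cc(OC)c1OC` differs from compound 2 by 3,4,5-trimethoxyphenyl in place of 4-fluorophenyl on an aromatic carbon. Among the compounds with values here, no measured step covers an exchange of this kind; the only step available concerns a different swap at the same aromatic carbon and moved nothing beyond the scatter. Compound 4 is therefore expected to show no step beyond the scatter, with a 1.1-fold lower number from compound 2 to compound 4 (0.04 log units; within the scatter) as the estimated change, and the estimate for compound 4 is 30000 nM within a range of 8000 nM to 120000 nM.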

Compound 4, half-maximal inhibitory concentration: 20900 nM
For compound 4 the middle estimate is 1.4-fold (0.16 log units) above the measured one; the measured number falls inside the stated range.
By their numbers in this assay, from the lowest: compounds 1, 4, 3 and 2 (each within the scatter of the next).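

In this assay, the step of a 1.6-fold lower number from compound 2 to compound 4 (0.20 log units; within the scatter) comes from 3,4,5-trimethoxyphenyl in place of 4-fluorophenyl, an exchange of the whole aryl group rather than of one halogen on it. This aromatic carbon thus accepts a group with more heavy atoms and with hydrogen-bond acceptors, without a step beyond the scatter. No measurement shown offers an explanation for this result. As far as these compounds go, it remains open whether an amine or a carboxylic acid on this aromatic carbon would move the number beyond the scatter.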